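A few compounds are considered here, and "the series" means these few. Any claim that something is new, unique, unknown or untested is made for them only; others in the source may bear on it.

Compound 1 `CC1=C(C(=O)OC(C)(C)C)C(c2ccco2)NC(=O)N1C` gives 54% in an assay on membranes from HeLa cells for displacement of a labelled ligand from adenosine receptor A3 (Homo sapiens), read by scintillation counting, with a stated time of 180 min, tested at 1 uM; a higher number here means more inhibition at the concentration tested (going by the name of the read-out), a lower number less inhibition. Compound 2 `CC1=C(C(=O)OC(C)(C)C)C(c2ccoc2)NC(=O)N1C` differs by furan-3-yl in place of furan-2-yl on a saturated ring carbon and gives 12% in this assay; the step is a number 42 percentage points lower from compound 1 to compound 2 (beyond the scatter). Compound 3 `CC1=C(c2ncc(C)o2)C(c2ccco2)NC(=O)N1` gives 4% in this assay; how its core differs from that of compound 1 is not broken down here, and its value stands nearest to that of compound 2. Compound 4 `CC1=C(c2ncc(C)o2)C(c2ccoc2)NC(=O)N1` is not yet measured. It differs from compound 3 by furan-3-yl in place of furan-2-yl on a saturated ring carbon, the same kind of change as from compound 1 to compound 2, but here the saturated ring carbon sits next to the ring atom that bears a 5-methyl-1,3-oxazol-2-yl group rather than a tert-butoxycarbonyl group. For compound 4 a much smaller step, a number 2 percentage points lower from compound 3 to compound 4 (within the scatter), is expected in this assay because compound 3 already gives 4%. Compound 4 is thus estimated at 2%, between -8% and 12%.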

Compound 4, a percentage reported as inhibition, at one concentration (the size of the read-out at that concentration, not a potency): 1%
Compound 4: the middle estimate sits 1 percentage points above what was measured; the measured number falls inside the stated range.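

In this assay the change from furan-2-yl to furan-3-yl on the saturated ring carbon does not carry over at one size between the two cores: the same change on two cores in this assay, a number 42 percentage points lower (beyond the scatter) from compound 1 to compound 2 and a number 3 percentage points lower (within the scatter) from compound 3 to compound 4, 39 percentage points apart, beyond the scatter of two such steps

On the core with the 5-methyl-1,3-oxazol-2-yl group the result is a number 3 percentage points lower from compound 3 to compound 4 (within the scatter), starting from a number already close to zero. Among these compounds, this shows only that the two steps differ in size; with one pair on each core it gives no rule for other cores.

Which difference between the two cores goes with the smaller step stays open. Also open, as far as these compounds go, is the size of the same change with a carboxylic acid or a primary amide on the ring atom that bears the tert-butoxycarbonyl group.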